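The compounds below may be only part of what the source reports. "The series", "measured", "known", "first", "only" and "open" are said of these compounds alone.

In an assay for binding affinity to dual specificity mitogen-activated protein kinase kinase 4 (Homo sapiens), read by KINOMEscan, tested at 100 nM (on this read-out higher numbers stand for a weaker effect at the one concentration tested and lower numbers for a stronger effect), compound 1, `CCCS(=O)(=O)Nc1ccc(F)c(C(=O)c2n[nH]c3ncc(-c4ccccc4Cl)cc23)c1F`, gives 9.3%. Compound 2, `CCCS(=O)(=O)Nc1ccc(F)c(C(=O)c2n[nH]c3ncc(-c4ccc(C)cc4)cc23)c1F`, gives 5.4% in this assay, and compound 3, `CCCS(=O)(=O)Nc1ccc(F)c(C(=O)c2n[nH]c3ncc(-c4ccc(Cl)c(C(F)(F)F)c4)cc23)c1F`, gives 15%. The number for compound 2 is the smallest of the three, yet the gaps to compound 1 and to compound 3 both fall inside the usual scatter, so the three compounds cannot be told apart on these numbers.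

Compound 4, `CCCS(=O)(=O)Nc1ccc(F)c(C(=O)c2n[nH]c3ncc(-c4cccc(C(F)(F)F)c4)cc23)c1F`, is not yet measured. It differs from compound 2 in a single place: 3-(trifluoromethyl)phenyl in place of 4-methylphenyl on an aromatic carbon.

The measured steps all change the same aryl group at this same position. They are a number 3.9 percentage points lower from compound 1 to compound 2 (within the scatter), a number 5.7 percentage points higher from compound 1 to compound 3 (within the scatter) and a number 9.6 percentage points higher from compound 2 to compound 3 (within the scatter), each within the scatter. Because each of the steps of a number 3.9 percentage points lower from compound 1 to compound 2 (within the scatter), a number 5.7 percentage points higher from compound 1 to compound 3 (within the scatter) and a number 9.6 percentage points higher from compound 2 to compound 3 (within the scatter) stayed within the scatter, no step beyond it is expected in this assay here either. For compound 4 the estimated step is a number 4.6 percentage points higher from compound 2 to compound 4 (within the scatter). Compound 4 is therefore expected to give about 10%, most likely between 3% and 25%.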

Compound 4, a percentage reported as activity, at one concentration (the size of the read-out at that concentration, not a potency): 57%
Compound 4: middle estimate off by 47 percentage points, on the low side; the whole stated range lies below it.
By their numbers in this assay, from the lowest: compounds 2, 1 and 3 (each within the scatter of the next); then compound 4.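

Until now, each change of aryl group at this position stayed within the scatter, but in this assay the 3-(trifluoromethyl)phenyl group breaks that picture, with a number 51.6 percentage points higher from compound 2 to compound 4 (beyond the scatter) and a number 47.7 percentage points higher from compound 1 to compound 4 (beyond the scatter), and a higher number here means a weaker effect. The most telling pair differs only by a chloro group, as hydrogen in its place gives a number 42 percentage points higher from compound 3 to compound 4 (beyond the scatter), so a trifluoromethyl group on this aryl ring is compatible with a strong effect when the chloro is also present, but not in compound 4, where it stands alone. Nothing available explains this sharp difference.

As far as these compounds go, it remains open whether the loss is specific to trifluoromethyl or would also appear with 3-chlorophenyl or 3-methylphenyl. A 4-(trifluoromethyl)phenyl group would show whether moving the same group around the ring restores the effect.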